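Chlorophenyl position across two cores: working notes

This account rests on a few compounds, and the source may have more. Where it says the series, first, only, none or still open, it means among the compounds named here.

Measured so far in a functional assay on MCF7 cells (Homo sapiens) for cytotoxicity, read by MTT assay, with a stated time of 72 h; on this read-out lower numbers stand for stronger inhibition and higher numbers for weaker inhibition:
- compound 1, `COc1cccc(/C=C2\CCC/C(=C\c3cccc(Cl)c3)C2=O)c1OC`, gives 12000 nM
- compound 2, `COc1cccc(/C=C2\CCC/C(=C\c3ccc(Cl)cc3)C2=O)c1OC`, gives 10300 nM
- compound 3, `COc1ccc(/C=C2\CCC/C(=C\c3cccc(Cl)c3)C2=O)cc1OC`, gives 6000 nM

Compounds 1 and 2 share one core and differ only in the chlorophenyl group: 4-chlorophenyl in place of 3-chlorophenyl on a double-bonded chain carbon bound to a double-bonded ring carbon. That change gives a 1.2-fold lower number from compound 1 to compound 2 (0.07 log units; within the scatter), so the two values read as equal within the usual scatter. Compound 3 carries a second core with the 3-chlorophenyl group; the difference between the two cores is not broken down here. Its value sits lowest of the three numbers, but its gaps to compound 2 and to compound 1 are both within the scatter, so no order among the three is claimed.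

Compound 4, `COc1ccc(/C=C2\CCC/C(=C\c3ccc(Cl)cc3)C2=O)cc1OC`, is not yet measured. It stands to compound 3 as compound 2 stands to compound 1: 4-chlorophenyl in place of 3-chlorophenyl on a double-bonded chain carbon bound to a double-bonded ring carbon. The place is the same in both pairs, so this is the same change made on the second core. Going by the values given here, with only one measured instance of the change, and that one within the scatter, the expectation for compound 4 is a step of the same small size: a 1.2-fold lower number from compound 3 to compound 4 (0.08 log units; within the scatter) is estimated, resting on compound 1 to compound 2 giving a 1.2-fold lower number from compound 1 to compound 2 (0.07 log units; within the scatter). Compound 4 is therefore expected at about 5000 nM in this assay, with a plausible range from 2500 nM to 10000 nM.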

Compound 4, half-maximal inhibitory concentration: 6300 nM
Beside the measured number, compound 4's estimate is 1.3-fold (0.10 log units) below it; low and high end bracket the measured number.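

In this assay, 4-chlorophenyl in place of 3-chlorophenyl on a double-bonded chain carbon bound to a double-bonded ring carbon gives a 1.1-fold higher number from compound 3 to compound 4 (0.02 log units; within the scatter). Set beside the same change on the core of compound 1, the new step does not differ from the earlier one: the same change on two cores in this assay, a 1.2-fold lower number (0.07 log units; within the scatter) from compound 1 to compound 2 and a 1.1-fold higher number (0.02 log units; within the scatter) from compound 3 to compound 4, 1.2-fold (0.09 log units) apart, within the scatter of two such steps. Going by these compounds alone, on these two cores the change carries over as a step within the scatter on each, so swapping 3-chlorophenyl for 4-chlorophenyl leaves the read-out without a readable shift, but this does not show that the two cores would respond alike to a change with a step beyond the scatter, and two pairs give no direction for the step and support no claim beyond these four compounds.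

As far as these compounds go, only 3-chlorophenyl and 4-chlorophenyl appear at this place, so it remains open whether a group such as an aminophenyl or a carboxylic acid on the phenyl ring would give a step beyond the scatter, and whether that step would hold on both cores. Also open, from the compounds shown here alone, is what the same change would do on a core carrying an amine or a longer chain in place of a methoxy group.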